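The compounds below may be only part of what the source reports. "The series", "measured", "known", "first", "only" and "open" are said of these compounds alone.

Compound 1 `O=C(CCCc1ccccc1)Nc1nc2ccccc2c(=O)s1` — > 1000 nM
Compound 2 `COc1cccc(/C=C/CC(=O)Nc2nc3ccccc3c(=O)s2)c1` — >= 1000 nM

In an assay on CHO cells for displacement of a labelled ligand from adenosine receptor A2b (Homo sapiens), read by scintillation counting, with a stated time of 75 min (a lower number here means a stronger inhibitor, a higher number a weaker inhibitor), compound 1 gives > 1000 nM, which is a limit of the assay rather than a number. In this assay compound 2 gives >= 1000 nM, again only a limit. Since both values shown are limits, compound 2 cannot be placed above or below compound 1; it simply sits at the limit of >= 1000 nM in this assay, at which 1 of the 2 values shown sits.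

Compound 3 `O=C(C/C=C/c1cccc(Cl)c1)Nc1nc2ccccc2c(=O)s1` differs from compound 2 by chloro in place of methoxy on an aromatic carbon. Among the measured compounds shown here, no step between measured compounds exists to guide the size of this change. The step that the limit leaves unreadable from compound 2 to compound 3 is expected to stay within the usual scatter. Compound 3 is therefore estimated at 2000 nM, within 700 nM to 8000 nM.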

Compound 3, inhibition constant: > 1000 nM
Compound 3 gave a limit, no number; the forecaster's own chance of this, stated with the estimate: 70%; the middle value lies beyond the limit too.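

No step can be read from compound 2 to compound 3, since each gives only a limit in this assay, not a number. The compounds shown leave open how strongly any of them binds, and whether methoxy or chloro gives the stronger inhibitor.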